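A few compounds are considered here, and "the series" means these few. Any claim that something is new, unique, unknown or untested is made for them only; others in the source may bear on it.

Compound 1 `C/C(=C\CC/C(C)=C/CC[C@@H]1[C@@]2(C)CCC(=O)C(C)(C)[C@H]2CC[C@@]1(C)O)CC/C=C(\C)C(=O)OCc1cn(-c2ccc(C(F)(F)F)cc2)nn1` opens the series in a functional assay on MDA-MB-231 cells (Homo sapiens) for antiproliferative activity, read by MTT assay, with a stated time of 48 h; a lower number here means a stronger inhibitor, a higher number a weaker inhibitor. In this assay compound 1 gives only a limit, > 150000 nM. Compound 2 `C/C(=C\CC/C(C)=C/CC[C@@H]1[C@@]2(C)CCC(=O)C(C)(C)[C@H]2CC[C@@]1(C)O)CC/C=C(\C)C(=O)OCc1cn(-c2ccccc2F)nn1` likewise gives only a limit in this assay, > 150000 nM. The step that the two limits leave unreadable from compound 1 to compound 2 thus cannot be sized, as the limit of > 150000 nM in this assay, at which 2 of the 2 values shown sit, shows. Compound 3 `C/C(=C\CC/C(C)=C/CC[C@@H]1[C@@]2(C)CCC(=O)C(C)(C)[C@H]2CC[C@@]1(C)O)CC/C=C(\C)C(=O)OCc1cn(-c2cccc(F)c2)nn1` differs from compound 2 by 3-fluorophenyl in place of 2-fluorophenyl on an aromatic nitrogen. Within the data shown here, only that unreadable step bears on this change, so no shift beyond the scatter is expected, and the expected step that the limit leaves unreadable from compound 2 to compound 3 is taken as flat. Compound 3 is therefore estimated at 200000 nM, ranging from 100000 nM to 500000 nM, and most likely again reported only as a limit.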

Compound 3, half-maximal inhibitory concentration: 144000 nM
Beside the measured number, compound 3's estimate is 1.4-fold (0.14 log units) above it; low and high end bracket the measured number.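

In this assay, among these compounds, compound 3 gives the first value that is a number rather than a limit, 144000 nM. With 3-fluorophenyl on the aromatic nitrogen, the readable change is an at least 1.0-fold lower number from compound 2 to compound 3 (0.01 log units; that floor lies within the scatter), and against the 4-(trifluoromethyl)phenyl group it is an at least 1.0-fold lower number from compound 1 to compound 3 (0.01 log units; that floor lies within the scatter); neither floor establishes a shift beyond the scatter. The effect of this change therefore cannot be sized: the limit of > 150000 nM in this assay, at which 2 of the 3 values shown sit.

Going by these compounds, whether an amine or a carboxylic acid on the phenyl ring would bring the values clearly into a measurable range remains open, as does the effect of a 4-fluorophenyl group.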